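The compounds below may be only part of what the source reports. "The series", "measured", "known", "first", "only" and "open" are said of these compounds alone.

Measured compounds in an in vitro assay on HEK385-7 cells for displacement of a labelled ligand from prostaglandin D2 receptor 2 (Homo sapiens); on this read-out lower numbers stand for stronger inhibition and higher numbers for weaker inhibition:

compound 1, `CCC(c1ccccc1)c1nc(-c2ccc(Cl)cc2)c(CC(=O)O)s1`: 190 nM
compound 2, `O=C(O)Cc1sc(COc2ccc(Cl)cc2)nc1-c1ccc(Cl)cc1`: 32 nM
compound 3, `O=C(O)Cc1sc(C(c2ccc(F)cc2)c2ccc(F)cc2)nc1-c1cccc(F)c1`: 1.4 nM

Compound 3 stands lowest of the three numbers in this assay. The nearest value belongs to compound 2 and the furthest to compound 1, and both gaps lie beyond the usual scatter, so compound 3 is the strongest of the measured set.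

Compound 4, `O=C(O)Cc1sc(C(c2ccc(F)cc2)c2ccc(F)cc2)nc1-c1ccnc(N2CCC2)c1`, has not been measured in this assay. Within the data shown here, its single change from compound 3 is 2-(azetidin-1-yl)pyridin-4-yl in place of 3-fluorophenyl on an aromatic carbon. Among the measured compounds shown here, no measured pair in this set shows an exchange of this kind, so the size of the step cannot be read from the numbers in hand. The starting point is strong, because compound 3 gives 1.4 nM in this assay, and a step of moderate size towards weaker inhibition is expected, a 3.6-fold higher number from compound 3 to compound 4 (0.55 log units; beyond the scatter), though a result within the scatter of compound 3 would not be surprising. For compound 4 the estimated value in this assay is 5 nM, with an expected range from 1.5 nM to 20 nM.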

Compound 4, half-maximal inhibitory concentration: 660 nM
Estimate against measurement, compound 4: 130-fold (2.12 log units) below; the whole stated range lies below it.
By their numbers in this assay, from the lowest: compound 3; then compound 2; then compound 1; then compound 4.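

At the aromatic carbon next to the ring atom that bears a carboxymethyl group, replacing 3-fluorophenyl with 2-(azetidin-1-yl)pyridin-4-yl gives a large loss in this assay, a 470-fold higher number from compound 3 to compound 4 (2.67 log units; beyond the scatter), so this position does not tolerate every aromatic group. Among these compounds, this is the only step that can be read at a single place; the other compounds differ from one another in more than one place, and no steps can be read among them. Nothing available explains the size of this loss.

On these data alone, the exchange changes the ring and adds the azetidine at once, so the source of the loss remains open. A plain pyridin-4-yl and a 3-(azetidin-1-yl)phenyl would separate these two changes, and a morpholine in place of the azetidine would test how much the amine itself matters.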